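Swapping an amide for fluorine on a weak growth inhibitor

The source may report more compounds than this note shows. Statements on the series, on what has been measured and on what is new or still open speak of the compounds shown alone.

Compound 1, with the structure `CCC1C(=O)N(C)c2cnc(-n3ccc4cc(C(=O)NC)ccc43)nc2N1c1ccn(C)n1`, was tested in a functional assay on MCF7 cells (Homo sapiens) for antiproliferative activity, read by CCK-8 assay, with a stated time of 72 h (on this read-out higher numbers stand for weaker inhibition of growth and lower numbers for stronger inhibition of growth), where compound 1 gives 35400 nM. Among the three compounds measured, this is the highest number, meaning compound 1 is the weakest inhibitor of the set. Compound 3, `CCC1C(=O)N(C)c2cnc(Nc3ccc(S(=O)(=O)NC)cc3)nc2N1c1ccn(C)n1`, lies nearest to it and gives 3750 nM in this assay. Compound 2, `CC[C@@H]1C(=O)N(C)c2cnc(-n3ccc4cc(C(=O)NCC(C)C)ccc43)nc2N1C1CCCC1`, stands furthest away and gives 953 nM in this assay. Both gaps to compound 1 lie beyond the usual scatter of repeated measurements.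

Compound 4, `CCC1C(=O)N(C)c2cnc(-n3ccc4cc(F)ccc43)nc2N1c1ccn(C)n1`, has not yet been measured. It differs from compound 1 in one place: fluoro in place of methylcarbamoyl on an aromatic carbon. Among the compounds with values here, no measured pair in this set shows the same change, so there is no direct step to lean on. The amide that leaves carries the only hydrogen-bond donor and acceptor at that position, while the entering fluoro carries none, and the closest measured compound, compound 2, keeps an amide at that position. The step from compound 1 to compound 4 is therefore expected to be small or slightly unfavorable, a 1.4-fold higher number from compound 1 to compound 4 (0.15 log units; within the scatter). In this assay compound 4 is expected to give about 50000 nM, with a range from 15000 nM to 150000 nM.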

Compound 4, concentration for 50% growth inhibition: 24700 nM
For compound 4 the middle estimate is 2.0-fold (0.31 log units) above the measured one; the range from low to high includes it.
By their numbers in this assay, from the lowest: compound 2; then compound 3; then compounds 4 and 1 (each within the scatter of the next).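

In this assay, within the data shown here, fluoro in place of methylcarbamoyl on this aromatic carbon gives a 1.4-fold lower number from compound 1 to compound 4 (0.16 log units; within the scatter), the first direct reading of a change at this position. For this pair, the amide with its hydrogen-bond donor and acceptor can give way to a single fluorine atom with no shift that stands clear of the usual scatter, so that hydrogen-bonding amide is not shown to matter for growth inhibition on this core. No measurement offered here gives a reason for this result.

The compounds shown leave open whether another group on this aromatic carbon, such as an amine, a carboxylic acid or a longer chain, would move the number beyond the scatter. They also leave open whether the same swap would give a similar step on the more active background of compound 2.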